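Replacing the Amide of Compound 3 with a Butynyl Ester

This account rests on a few compounds, and the source may have more. Where it says the series, first, only, none or still open, it means among the compounds named here.

Compound 3 `CCn1c(C(=O)NCCN(C)C)ccc1C(CC)(CC)c1ccc(OCC(O)C(C)(C)C)c(C)c1` gives the lowest of the two numbers shown in an assay on HL-60 cells for agonist activity at vitamin D3 receptor (Homo sapiens), read by microscopy, with a stated time of 96 h (on this read-out lower numbers stand for an effect already at smaller amounts and higher numbers for an effect only at larger amounts of compound), at 14 nM. Its nearest neighbour is compound 1 `CCn1c(C(=O)NCCN(C)C)ccc1C(CC)(CC)c1ccc(OCC(=O)C(C)(C)C)c(C)c1`, which in this assay gives 77 nM; the step of a 5.5-fold lower number from compound 1 to compound 3 (0.74 log units; beyond the scatter) rests on 1-hydroxy-2,2-dimethylpropyl in place of (tert-butyl)carbonyl on a saturated chain carbon bound to an oxygen on an aromatic ring. Compound 2 `CCOC(=O)CC(C)OC(=O)c1ccc(C(CC)(CC)c2ccc(OCC(=O)C(C)(C)C)c(C)c2)n1CC` returns in this assay only a limit, > 50000 nM. Of the three values shown, this one sits at the limit (the limit of > 50000 nM in this assay, at which 1 of the 3 values shown sits). The step from compound 1 to compound 2 exchanges a group of 6 heavy atoms for a group of 9 heavy atoms on a carbonyl carbon, and the number rises sharply: an at least 640-fold higher number from compound 1 to compound 2 (2.81 log units; beyond the scatter).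

Compound 4 `C#CCCOC(=O)c1ccc(C(CC)(CC)c2ccc(OCC(O)C(C)(C)C)c(C)c2)n1CC` has not yet been measured. It differs from compound 3 in one place: (but-3-yn-1-yl)oxy in place of (2-(dimethylamino)ethyl)amino on a carbonyl carbon. The step from compound 1 to compound 2 bears on this change because an at least 640-fold higher number from compound 1 to compound 2 (2.81 log units; beyond the scatter) also replaced the group on that carbonyl carbon with an ester-type group. A large rise is therefore expected for compound 4 in this assay, a 570-fold higher number from compound 3 to compound 4 (2.76 log units; beyond the scatter). The estimate for compound 4 is 8000 nM, within a range from 800 nM to 50000 nM, with a fair chance that only a limit is returned.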

Compound 4, half-maximal effective concentration: 1030 nM
Estimate against measurement, compound 4: 7.8-fold (0.89 log units) above; measured number inside the range.
By their numbers in this assay, from the lowest: compound 3; then compound 1; then compound 4. At a limit, above all of these: compound 2.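

In this assay, (but-3-yn-1-yl)oxy in place of (2-(dimethylamino)ethyl)amino on a carbonyl carbon gives a 74-fold higher number from compound 3 to compound 4 (1.87 log units; beyond the scatter), which shows that this position is sensitive to the change in a compound that carries the 1-hydroxy-2,2-dimethylpropyl group, and puts a readable size on that change. Compound 2, the earlier ester on this carbonyl carbon, gave only a limit of the assay, > 50000 nM. Compound 4 instead returns a number, so an ester here does not by itself push the read-out to that limit, although compound 2 and compound 4 also differ elsewhere and cannot be compared directly.

The compounds shown leave open whether the rise goes with the ester link itself or with the departure of the 2-(dimethylamino)ethyl chain, and no measured property settles this. An amide carrying the but-3-yn-1-yl chain and an ester carrying the 2-(dimethylamino)ethyl chain would separate these two parts of the change, and a carboxylic acid on this carbonyl carbon would show how much depends on having any such chain.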